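The source may hold more compounds than are shown below. What is called first, only, known or untested is meant among the compounds shown, and "the series" means these compounds.

Three compounds that share the core of compound 1 `CCCCOc1ccc(Nc2nc3nonc3nc2O)cc1` have been measured in an assay on mitochondria from L6 cells (Rattus norvegicus) for activation, with a stated time of 90 min; a higher number here means that more compound is needed for the effect, a lower number that less compound is needed. Compound 1 gives 3700 nM, the second highest of the three numbers. Compound 2 `CCCCCc1ccc(Nc2nc3nonc3nc2O)c(F)c1` gives 1500 nM in this assay, a lower number than compound 1 by a margin that lies beyond the usual scatter. Compound 3 `Oc1nc2nonc2nc1Nc1ccccc1OC(F)(F)F` gives 7100 nM in this assay, a number that lies within the scatter of compound 1, so the two cannot be ordered against each other. Among the compounds with values here, none of these three differs from another in a single place, so no step between measured compounds can be read off from them.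

Compound 4 `Oc1nc2nonc2nc1Nc1ccc(OC(F)(F)C(F)F)cc1` has not yet been measured. It differs from compound 1 in one place: 1,1,2,2-tetrafluoroethyl in place of butyl on an oxygen on an aromatic ring. Within the data shown here, no measured pair isolates a change of this kind, so the direction and size of the step can only be estimated. Among the measured compounds shown here, the group that leaves and the group that enters carry the same count of hydrogen-bond donors and acceptors, and nothing among the measured compounds shows which way a fluorinated chain at this oxygen would move the number. Compound 4 is therefore expected to give about 4500 nM in this assay, with a range from 1800 nM to 11000 nM. The expected step is a 1.2-fold higher number from compound 1 to compound 4 (0.09 log units; within the scatter), which is estimated to stay within the scatter.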

Compound 4, half-maximal effective concentration: 7000 nM
Beside the measured number, compound 4's estimate is 1.6-fold (0.19 log units) below it, within the range that was stated.
By their numbers in this assay, from the lowest: compound 2; then compounds 1, 4 and 3 (each within the scatter of the next).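

Within the data shown here, this is the first single-place change that can be read at the oxygen on the aromatic ring of the shared core: in this assay, 1,1,2,2-tetrafluoroethyl in place of butyl gives a 1.9-fold higher number from compound 1 to compound 4 (0.28 log units; within the scatter). That step lies within the scatter, so compound 1 and compound 4 cannot be ordered against each other, and this exchange of butoxy for 1,1,2,2-tetrafluoroethoxy produces no measurable difference in this assay, even though the entering group swaps two of the chain's carbons and adds four fluorines. No other measurement shown here bears on this result, so it remains an observation without an explanation.

The step alters chain length and fluorine content together, so this one pair cannot separate the two, and a plain ethyl or a fully carbon-and-hydrogen chain longer than butyl, such as hexyl, on the same oxygen would be needed to do that. From the compounds shown here alone, it also remains open whether the same tolerance would hold for an amine or a carboxylic acid at the end of the chain, or for an amine in place of the oxygen itself.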